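Swapping an Ether Chain for Phenylsulfonyl

The compounds below may be only part of what the source reports. "The series", "measured", "known", "first", "only" and "open" are said of these compounds alone.

- Compound 1 `Cn1c2cnc1OCCCCCCCCOc1cc(F)ccc1-2`: 46000 nM
- Compound 2 `C=CCCCCOc1ccccc1-c1cnc(OCCCC=C)n1C`: 28000 nM
- Compound 3 `C#CCCCCOc1ncc(-c2ccccc2OC)n1C`: 21000 nM

In a functional assay on PC-3 cells (Homo sapiens) for inhibition, read by colorimetric assay and MTT assay, with a stated time of 72 h (a higher number here means a weaker inhibitor, a lower number a stronger inhibitor), compound 2 gives 28000 nM, which lies within the usual scatter of both compound 1 and compound 3, so it cannot be set apart from either.

Compound 4 `C=CCCCCOc1ccccc1-c1cnc(S(=O)(=O)c2ccccc2)n1C` carries phenylsulfonyl in place of (pent-4-en-1-yl)oxy on an aromatic carbon. For the measured compounds named here, no measured compound carries this group, and no measured pair differs in only one place, so the data offer no direct guide. Compound 1 at 46000 nM and compound 3 at 21000 nM differ in structure yet stay in the same broad range as compound 2, so no change beyond the scatter is expected. The estimated change is a 1.4-fold lower number from compound 2 to compound 4 (0.15 log units; within the scatter). Compound 4 is expected at 20000 nM, with an estimated range of 6000 nM to 50000 nM.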

Compound 4, half-maximal inhibitory concentration: 33000 nM
For compound 4 the middle estimate is 1.7-fold (0.22 log units) below the measured one; the measured number falls inside the stated range.
By their numbers in this assay, from the lowest: compounds 3, 2, 4 and 1 (each within the scatter of the next, the first and the last beyond it).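

For the compounds shown here, on the aromatic carbon between two ring nitrogen atoms, putting phenylsulfonyl in place of (pent-4-en-1-yl)oxy gives a 1.2-fold higher number from compound 2 to compound 4 (0.07 log units; within the scatter) in this assay and is the first one-place comparison in this set. This position therefore takes a group with its own six-membered aromatic ring, and one more hydrogen-bond acceptor, with no readable change in the number. From the compounds shown here alone, whether an amine or a carboxylic acid at this position would shift the number stays open. So does the effect of a longer chain there. Nothing measured here accounts for the result.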